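Ring nitrogen substituent series: amide in place of pyridylmethyl

The source may hold more compounds than are shown below. What is called first, only, known or untested is meant among the compounds shown, and "the series" means these compounds.

Compound 1 `CCCCNc1nc(N)nc2c1CN(C)CC2` and compound 2 `CCCCNc1nc(N)nc2c1CN(Cc1cccnc1)CC2` share one core. For the measured compounds named here, in an assay on HEK293 cells for agonist activity at Toll-like receptor 8 (Homo sapiens), read by a luciferase reporter, with a stated time of 6 h (on this read-out higher numbers stand for an effect only at larger amounts of compound and lower numbers for an effect already at smaller amounts), compound 1 gives 0.03 uM, and compound 2 gives 0.13 uM, the highest of the two numbers; the only step known, a 4.3-fold higher number from compound 1 to compound 2 (0.64 log units; beyond the scatter), shows that what sits on the ring amine nitrogen shifts the read-out modestly. Compound 3 `CCCCNc1nc(N)nc2c1CN(C(=O)CC)CC2` differs from compound 2 by propanoyl in place of (pyridin-3-yl)methyl on an amine nitrogen in a ring. Going by the values given here, no measured step covers an acyl group at this position; the step from compound 1 to compound 2 points to a modest effect at most. Compound 3 is therefore expected near compound 2 or somewhat higher, a 2.3-fold higher number from compound 2 to compound 3 (0.36 log units; beyond the scatter), with an estimate of 0.3 uM and a range from 0.08 uM to 1.2 uM.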

Compound 3, minimum effective concentration: 0.4 uM
Estimate against measurement, compound 3: 1.3-fold (0.12 log units) below; the range from low to high includes it.
By their numbers in this assay, from the lowest: compound 1; then compound 2; then compound 3.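

In this assay an acyl group on the amine nitrogen in a ring now has measured steps: a 3.1-fold higher number from compound 2 to compound 3 (0.49 log units; beyond the scatter) and a 13-fold higher number from compound 1 to compound 3 (1.12 log units; beyond the scatter). The second step, with propanoyl in place of methyl, is large, so this nitrogen can move the read-out much further than the step to the pyridylmethyl compound alone showed. No evidence available here accounts for these steps.

From the compounds shown here alone, it remains open whether the carbonyl or the chain carries the shift: a propyl group would separate the two. Acetyl or a longer acyl chain would show how the number follows chain length.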